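A few compounds are considered here, and "the series" means these few. Any claim that something is new, unique, unknown or untested is made for them only; others in the source may bear on it.

In an ADME assay on microsomes from liver (Rattus norvegicus) for metabolic stability (on this read-out lower numbers stand for a shorter-lived compound and higher numbers for a longer-lived compound), compound 1 `COc1cc(OCc2cccc(-c3cnc(OC)nc3)c2)c2cc(-c3cn4nc(OC)sc4n3)oc2c1` gives 1.03 h and compound 2 `COc1cc(OCc2cccc(-c3cnc(OC)cn3)c2)c2cc(-c3cn4nc(OC)sc4n3)oc2c1` gives 1.62 h while compound 3 `COc1ccc(-c2cccc(COc3cc(OC)cc4oc(-c5cn6nc(OC)sc6n5)cc34)c2)nc1` gives 0.317 h as the lowest of the three numbers. Compound 4 `COc1cc(OCc2cccc(-c3ccc(C#N)cc3)c2)c2cc(-c3cn4nc(OC)sc4n3)oc2c1` departs from compound 3 by one exchange 4-cyanophenyl in place of 5-methoxypyridin-2-yl on an aromatic carbon with 4-cyanophenyl in place of 5-methoxypyridin-2-yl on an aromatic carbon. The measured exchanges at that place are a 3.2-fold lower number from compound 1 to compound 3 (0.51 log units; beyond the scatter) and a 5.1-fold lower number from compound 2 to compound 3 (0.71 log units; beyond the scatter) as modest steps beyond the scatter, along with a 1.6-fold higher number from compound 1 to compound 2 (0.20 log units; within the scatter) as a step within it. None of them brings in 4-cyanophenyl, so the guide is indirect. Compound 3 at 0.317 h is the low outlier of this small set, so a modest rise is expected. The estimated step is a 2.2-fold higher number from compound 3 to compound 4 (0.34 log units; beyond the scatter) and no larger than those two. For compound 4 the estimated value is 0.7 h within a range from 0.25 h to 2 h as expected.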

Compound 4, half-life: 1.67 h
Estimate against measurement, compound 4: 2.4-fold (0.38 log units) below, within the range that was stated.
By their numbers in this assay, from the lowest: compound 3; then compounds 1, 2 and 4 (each within the scatter of the next).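

In this assay a ring of carbon only carrying a nitrile serves at this place, and the exchange for 5-methoxypyridin-2-yl gives a 5.3-fold higher number from compound 3 to compound 4 (0.72 log units; beyond the scatter) as a modest step beyond the scatter. Against the other two groups the same ring gives a 1.0-fold higher number from compound 2 to compound 4 (0.01 log units; within the scatter) and a 1.6-fold higher number from compound 1 to compound 4 (0.21 log units; within the scatter) with both steps within the scatter, so among these four compounds only compound 3 stands apart and a ring nitrogen is not required to reach the level of compound 1 and compound 2. No measurement given here accounts for these differences.

Going by these compounds, whether 4-methoxyphenyl would match 4-cyanophenyl remains open. So does the outcome with a saturated amine such as morpholine at this place.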